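The source may hold more compounds than are shown below. What is called first, only, known or untested is meant among the compounds shown, and "the series" means these compounds.

Measured compounds:
compound 1 `COc1ccc(-c2cc3nccc(-c4cc(OC)c(OC)c(OC)c4)n3n2)cc1N`: 138 nM
compound 2 `COc1cc(-c2cc3nccc(-c4c[nH]c5ccccc45)n3n2)cc(OC)c1OC`: > 10000 nM

Going by the values given here, in a functional assay on A549 cells (Homo sapiens) for inhibition, read by CCK-8 assay, with a stated time of 48 h (a lower number here means a stronger inhibitor, a higher number a weaker inhibitor), compound 1 gives 138 nM, the only number among the values shown. Compound 2 gives only a limit in this assay, > 10000 nM, and that limit is the limit of > 10000 nM in this assay, at which 1 of the 2 values shown sits. Among the compounds with values here, no step between measured compounds is available, so the size of a single structural change here is unknown.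

Compound 3 `COc1cc(-c2ccnc3cc(-c4ccc5ccn(C)c5c4)nn23)cc(OC)c1OC` differs from compound 1 in one place: 1-methyl-1H-indol-6-yl in place of 3-amino-4-methoxyphenyl on an aromatic carbon. The change removes the only hydrogen-bond donor of the group that leaves and brings a fused five- and six-membered ring system in its place. Without a measured step to lean on, the expectation rests on this change alone. A step from compound 1 to compound 3 of an 11-fold higher number from compound 1 to compound 3 (1.04 log units; beyond the scatter) is expected, a weakening that goes beyond the usual scatter. Compound 3 is therefore estimated to give 1500 nM in this assay, with a range from 300 nM to 8000 nM.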

Compound 3, half-maximal inhibitory concentration: 829 nM
Estimate against measurement, compound 3: 1.8-fold (0.26 log units) above; measured number inside the range.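

Going by these compounds alone, this is the first measured step at this aromatic carbon of the five-membered ring with 2 nitrogen. In this assay, 1-methyl-1H-indol-6-yl in place of 3-amino-4-methoxyphenyl gives a 6.0-fold higher number from compound 1 to compound 3 (0.78 log units; beyond the scatter), so the group at this place clearly affects the read-out. Even so, compound 3 still gives a measured number, 829 nM, which shows that a fused ring system can stand here without the activity being lost. Nothing in the data shown explains the size of this step.

The swap changes the whole group at once, so the contribution of the amine cannot be separated from that of the ring system. A phenyl ring carrying a hydroxyl group in place of the amine, or the indole without its methyl group, would help to separate them.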